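Adding a second methyl to the anilino ring

The source may hold more compounds than are shown below. What is called first, only, known or untested is meant among the compounds shown, and "the series" means these compounds.

Of the compounds shown here, three of a shared core have been measured in a functional assay on MCF7 cells (Homo sapiens) for inhibition, read by sulforhodamine B assay; on this read-out higher numbers stand for weaker inhibition and lower numbers for stronger inhibition. Compound 1 `O=C1C=C(Nc2ccc(I)cc2)C(=O)c2c1nc1n2[C@H]2OC[C@@H](O)[C@H]2OC1` gives 2230 nM, compound 2 `Cc1ccc(NC2=CC(=O)c3nc4n(c3C2=O)[C@H]2OC[C@@H](O)[C@H]2OC4)cc1` gives 1660 nM, and compound 3 `COc1cccc(NC2=CC(=O)c3c(nc4n3[C@H]3OC[C@@H](O)[C@H]3OC4)C2=O)c1` gives 3830 nM. Compound 2 thus stands within the scatter of compound 1 and beyond the scatter below compound 3. For the measured compounds named here, the only single-place step so far, a 1.3-fold lower number from compound 1 to compound 2 (0.13 log units; within the scatter), shows that swapping one small group on the aromatic ring changed little. Compound 4 `Cc1ccc(NC2=CC(=O)c3nc4n(c3C2=O)[C@H]2OC[C@@H](O)[C@H]2OC4)cc1C` differs from compound 2 by methyl in place of hydrogen on an aromatic carbon. Going by the values given here, no measured step adds a group to this ring, so the expectation rests on the small size of that one step, and a change in this assay no larger than the scatter is expected, a 1.1-fold lower number from compound 2 to compound 4 (0.04 log units; within the scatter). Compound 4 is therefore estimated at 1500 nM, within 700 nM to 3500 nM.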

Compound 4, half-maximal inhibitory concentration: 2080 nM
The estimate for compound 4 lay 1.4-fold (0.14 log units) below the measured number; the measured number falls inside the stated range.
By their numbers in this assay, from the lowest: compounds 2, 4, 1 and 3 (each within the scatter of the next, the first and the last beyond it).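

Adding a methyl ortho to the methyl already on the aromatic ring leaves the number in this assay almost where it was, with a 1.3-fold higher number from compound 2 to compound 4 (0.10 log units; within the scatter). Exchanging the 4-iodophenyl group for 3,4-dimethylphenyl also stays within the scatter, with a 1.1-fold lower number from compound 1 to compound 4 (0.03 log units; within the scatter), so this ring accepts a second methyl without a readable change. No measured evidence here says why these steps are so small.

As far as these compounds go, what remains open is whether this position responds to anything other than methyl. An amine, a carboxylic acid or a longer chain placed there could give a different answer.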